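Chloro at the core and cytotoxicity in colon cancer cells

The source may report more compounds than this note shows. Statements on the series, on what has been measured and on what is new or still open speak of the compounds shown alone.

The series rests on a shared core carrying a chloromethyl-benzyl group. Compound 1 `ClCc1ccccc1Cn1cnc2c(Cl)nc(Cl)nc21` bears two chloro groups on the core; in a functional assay on HCT-116 cells (Homo sapiens) for cytotoxicity, read by sulforhodamine B assay, with a stated time of 48 h (on this read-out higher numbers stand for lower toxicity in this test and lower numbers for higher toxicity in this test), compound 1 gives 750 nM. Compound 2 `ClCc1ccccc1Cn1cnc2c(Cl)ncnc21` keeps only one of them, and in this assay compound 2 gives 7080 nM. The change between them is chloro in place of hydrogen on an aromatic carbon, and it produced a step of a 9.4-fold lower number from compound 2 to compound 1 (0.97 log units; beyond the scatter). Compound 3 `ClCc1cccc(Cn2cnc3ncnc(Cl)c32)c1` has the same atoms as compound 2 joined differently; the difference between the two cores is not broken down here. In this assay compound 3 gives 9540 nM, a number within the scatter of that of compound 2, while compound 1 sits well below both.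

Compound 4 `ClCc1cccc(Cn2cnc3nc(Cl)nc(Cl)c32)c1` derives from compound 3 by chloro in place of hydrogen on an aromatic carbon, the same change as that from compound 2 to compound 1. The step to compound 4 is therefore expected to be an 8.7-fold lower number from compound 3 to compound 4 (0.94 log units; beyond the scatter) in this assay, resting on the step of a 9.4-fold lower number from compound 2 to compound 1 (0.97 log units; beyond the scatter) and on the value of compound 3, 9540 nM. For compound 4 the expected value in this assay is 1100 nM, likely between 400 nM and 3200 nM.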

Compound 4, concentration lethal to 50% of the cells: 4460 nM
Compound 4: middle estimate off by 4.1-fold (0.61 log units), on the low side; measured number above the stated range.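

In this assay, chloro in place of hydrogen on an aromatic carbon again goes with a lower number, here a 2.1-fold lower number from compound 3 to compound 4 (0.33 log units; beyond the scatter). The direction of the change is the same on both cores, but its size does not carry over from one core to the other: the same change on two cores in this assay, a 9.4-fold lower number (0.97 log units; beyond the scatter) from compound 2 to compound 1 and a 2.1-fold lower number (0.33 log units; beyond the scatter) from compound 3 to compound 4, 4.4-fold (0.64 log units) apart, beyond the scatter of two such steps. These two pairs show only that the size of the step differs between these two cores; they do not show what in the cores sets the gap, or what size the step would take on any further core.

The compounds shown leave open how an amine, a methoxy group or a longer chain would compare with chloro on the carbon between two ring nitrogen atoms. Also open, on these data alone, is what would follow if a hydroxymethyl or plain methyl group took the place of the chloromethyl group, which all four compounds carry.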